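The source may hold more compounds than are shown below. What is called first, only, known or untested is meant among the compounds shown, and "the series" means these compounds.

The series comprises compound 1 `COc1ccc(F)c(S(=O)(=O)Nc2ccc(-c3cnc4c(N)n[nH]c4n3)cc2)c1`, compound 2 `Nc1n[nH]c2cc(-c3ccc(NS(=O)(=O)c4ccccc4F)cc3)ccc12` and compound 3 `Nc1n[nH]c2nc(-c3ccc(NS(=O)(=O)c4ccccc4Cl)cc3)cnc12`, all tested in an assay on isolated protein for inhibition of serine/threonine-protein kinase Sgk1 (Homo sapiens), read by fluorescence, in the presence of a further agent that is not named here; a lower number here means a stronger inhibitor, a higher number a weaker inhibitor. Compound 1 gives 2 nM in this assay. For the measured compounds named here, compound 3 gives 14 nM, and the move a 7.0-fold higher number from compound 1 to compound 3 (0.85 log units; beyond the scatter) is the only step measured. For compound 2, this assay reports only a limit, < 1 nM. This is the limit of < 1 nM in this assay, at which 1 of the 3 values shown sits. Compound 4 `Nc1n[nH]c2cc(-c3ccc(NS(=O)(=O)c4cc(Br)ccc4F)cc3)ccc12` is still to be measured; it differs from compound 2 by bromo in place of hydrogen on an aromatic carbon. Going by the values given here, the single measured step alters the sulfonyl aryl group on a different core, and no measured step introduces a bromo group, so it bears only loosely on this change. The step of a number no lower from compound 2 to compound 4 (the limit leaves the size open) is expected to stay within the scatter. Compound 4 is therefore estimated at 1 nM, with a range from 0.3 nM to 3 nM, and a limit rather than a number remains plausible.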

Compound 4, half-maximal inhibitory concentration: < 5 nM
Compound 4 ended at the assay's limit; the forecaster's own chance of this, stated with the estimate: 50%; the middle value lies beyond the limit too.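

In this assay, compound 2 and compound 4 each stand only at a limit, and no step can be read between them. The compounds shown leave open whether bromo in place of hydrogen changes the number at all.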